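This account rests on a few compounds, and the source may have more. Where it says the series, first, only, none or still open, it means among the compounds named here.

Values in an in vitro ADME assay on microsomes from liver (Homo sapiens) for metabolic stability; a lower number here means slower removal, a higher number faster removal of the compound:
- Compound 1 `Nc1nccc(Nc2ccc(Oc3ccc(Cl)cc3)cc2)n1`: 206 mL.min-1.g-1
- Compound 2 `Nc1ccnc(Nc2ccc(Oc3ccc(Cl)cc3)cc2)c1`: 14 mL.min-1.g-1
- Compound 3 `Nc1cnnc(Nc2ccc(Oc3ccc(Cl)cc3)cc2)c1`: < 14 mL.min-1.g-1 (a limit, not a number)

Compound 3 thus stands at a limit: the limit of < 14 mL.min-1.g-1 in this assay, at which 1 of the 3 values shown sits.

Compound 4 `Nc1nnc(Nc2ccc(Oc3ccc(Cl)cc3)cc2)s1` carries 5-amino-1,3,4-thiadiazol-2-yl in place of 5-aminopyridazin-3-yl on a nitrogen on an aromatic ring.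

Going by the values given here, the steps that bear on this also change the group on that nitrogen. From the compounds shown here alone, they are a 15-fold lower number from compound 1 to compound 2 (1.17 log units; beyond the scatter) and an at least 14-fold lower number from compound 1 to compound 3 (1.16 log units; beyond the scatter), both large, and a number no higher from compound 2 to compound 3 (the limit leaves the size open), whose size stays open. None of them involves a five-membered aromatic ring, so the swap is only loosely constrained.

A modest rise is expected, estimated as an at least 1.7-fold higher number from compound 3 to compound 4 (0.25 log units; that floor lies within the scatter), well short of those large steps.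

For compound 4 the estimate is 25 mL.min-1.g-1, with an expected range from 10 mL.min-1.g-1 to 120 mL.min-1.g-1.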

Compound 4, intrinsic clearance in microsomes: < 14 mL.min-1.g-1
Compound 4 was reported as a limit; the forecaster's own chance of this, stated with the estimate: 30%; middle value at least 1.7-fold (0.25 log units) away from the limit.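

In this assay compound 4 gives < 14 mL.min-1.g-1 as a limit, not a number. 5-Amino-1,3,4-thiadiazol-2-yl, a five-membered aromatic ring, thus also gives a low read-out on this nitrogen, with an at least 14-fold lower number from compound 1 to compound 4 (1.16 log units; beyond the scatter) as the step. There is also a number no higher from compound 2 to compound 4 (the limit leaves the size open). The step to compound 4 from compound 3 cannot be read, and the limit is shared: the limit of < 14 mL.min-1.g-1 in this assay, at which 2 of the 4 values shown sit.

From the compounds shown here alone, how far compound 3 and compound 4 actually lie apart in this assay stays open. So does the effect of replacing the ring amine of compound 4 with an acetamide or a methyl group.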